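A few compounds are considered here, and "the series" means these few. Any claim that something is new, unique, unknown or untested is made for them only; others in the source may bear on it.

Of the compounds shown here, three have so far been measured in an ADME assay on MDCKII-LE cells (Canis lupus familiaris) for permeability; a higher number here means that the compound crosses the layer faster, a lower number that the compound crosses the layer more slowly. Compound 1 (`Cc1cnc(NC(=O)c2cc(Oc3cnc(C(=O)N(C)C)cn3)c3cc(C)oc3c2)cn1`) gives 22.3 10^-6 cm/s, compound 2 (`Cc1cnc(NC(=O)c2cc(Oc3cnc(C(=O)N(C)C)cn3)c3cn(C)nc3c2)cn1`) gives 20.8 10^-6 cm/s and compound 3 (`Cc1cnc(NC(=O)c2cc(Oc3ccc(C(=O)N(C)C)cc3)c3cn(C)nc3c2)cn1`) gives 14.6 10^-6 cm/s. Compound 3 thus stands within the scatter of both compound 1 and compound 2, and the three numbers cannot be ranked.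

The next compound, compound 4 (`CCS(=O)(=O)c1ccc(Oc2cc(C(=O)Nc3cnc(C)cn3)cc3nn(C)cc23)cc1`), differs from compound 3 in one place: ethylsulfonyl in place of dimethylcarbamoyl on an aromatic carbon. Going by the values given here, no measured pair differs in only one place, and none of the three measured compounds carries ethylsulfonyl, so the data offer no direct precedent for this exchange. Compound 1 at 22.3 10^-6 cm/s and compound 3 at 14.6 10^-6 cm/s differ in more than one place yet remain within the scatter of each other, which gives some reason to expect no large move here.

In this assay the expected result is a slight upward move that stays within the scatter, an estimated 1.1-fold higher number from compound 3 to compound 4 (0.04 log units; within the scatter). For compound 4 the estimated value is 16 10^-6 cm/s, expected to fall between 8 10^-6 cm/s and 28 10^-6 cm/s.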

Compound 4, apparent permeability: 10.6 10^-6 cm/s
Compound 4: middle estimate off by 1.5-fold (0.18 log units), on the high side; the range from low to high includes it.
By their numbers in this assay, from the lowest: compounds 4, 3, 2 and 1 (each within the scatter of the next, the first and the last beyond it).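

Going by these compounds alone, this is the first exchange that can be read at a single place. In this assay, ethylsulfonyl in place of dimethylcarbamoyl on an aromatic carbon, para to a large group, gives a 1.4-fold lower number from compound 3 to compound 4 (0.14 log units; within the scatter), so this read-out does not separate the two groups at this position, although ethylsulfonyl enters with one more hydrogen-bond acceptor and one more double bond outside aromatic rings. No measurement is at hand that bears on this result.

As far as these compounds go, the exchange rests on one pair with one shared core, so it remains open whether ethylsulfonyl would read the same on the ring that compound 2 carries at this place, or on the core of compound 1. From the compounds shown here alone, it is also open whether a methylsulfonyl, a sulfonamide, a primary amine or a carboxylic acid at this position would stay as close to compound 3 in this assay as ethylsulfonyl does.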